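Clearance notes: removing one fluoro from the sulfonyl aryl

The source may report more compounds than this note shows. Statements on the series, on what has been measured and on what is new or still open speak of the compounds shown alone.

Measured so far:
- compound 1 `O=S(=O)(c1cc(F)cc(F)c1)c1cnc2c(F)cccc2c1-c1ccccc1F`: 0.09 mL/min
- compound 2 `O=S(=O)(c1cc(F)cc(F)c1)c1cnc2c(F)cccc2c1-c1cccc(Cl)c1`: 0.64 mL/min

In an ADME assay on microsomes from liver (Homo sapiens) for metabolic stability, tested at 2.5 uM (a higher number here means faster removal of the compound, a lower number slower removal), compound 2 gives the higher of the two numbers measured; the nearest is compound 1, which lies lower by a 7.1-fold higher number from compound 1 to compound 2 (0.85 log units; beyond the scatter). That step changed the aryl on the other side of the shared core, not the sulfonyl aryl.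

Compound 3 `O=S(=O)(c1cccc(F)c1)c1cnc2c(F)cccc2c1-c1cccc(Cl)c1` differs from compound 2 by hydrogen in place of fluoro on an aromatic carbon, so the 3,5-difluorophenyl becomes a 3-fluorophenyl. Among the compounds with values here, no measured step touches this sulfonyl aryl, and the one measured step concerns a different part of the molecule. Nothing here therefore anchors a direction for this assay beyond the scatter, and a step within the usual scatter is the plain expectation.

Compound 3 is accordingly expected at 0.8 mL/min, range 0.35 mL/min to 1.8 mL/min, i.e. a step of a 1.3-fold higher number from compound 2 to compound 3 (0.10 log units; within the scatter).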

Compound 3, intrinsic clearance in a liver preparation (reported as CLH), per the amount of preparation that the assay uses: 0.56 mL/min
The estimate for compound 3 lay 1.4-fold (0.15 log units) above the measured number; the measured number falls inside the stated range.
By their numbers in this assay, from the lowest: compound 1; then compounds 3 and 2 (each within the scatter of the next).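

Within the data shown here, replacing fluoro with hydrogen, so that the 3,5-difluorophenyl becomes a 3-fluorophenyl, is the first measured change at the sulfonyl aryl, and in this assay it gives a step within the scatter (a 1.1-fold lower number from compound 2 to compound 3 (0.06 log units; within the scatter)). This fluoro can therefore be removed from the compound 2 structure without a measurable change in this read-out, unlike the step beyond the scatter at the aryl on the other side of the shared core (a 7.1-fold higher number from compound 1 to compound 2 (0.85 log units; beyond the scatter)). No evidence on the cause of either outcome is available.

The compounds shown leave open whether the remaining fluoro on this aryl can also be removed, and whether an amine or a carboxylic acid at that place would stay within the scatter. They also leave open whether the same change would read alike with the 2-fluorophenyl of compound 1 in place of the 3-chlorophenyl.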